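The source may hold more compounds than are shown below. What is called first, only, known or untested is meant among the compounds shown, and "the series" means these compounds.

Measured so far in a functional assay on HEK293 cells for agonist activity at D(4) dopamine receptor (Homo sapiens), read by FLIPR; a lower number here means that less compound is needed, a higher number that more compound is needed for the effect:
compound 1 `COc1ccccc1C1CCN(CC(=O)Nc2cccc(C)c2)CC1` gives 420 nM
compound 2 `O=C(CN1CCC(c2cccc[n+]2[O-])CC1)Nc1cccc(F)c1` gives 160 nM

Compound 1 stands at the higher of the two numbers in this assay; compound 2 sits lower, and the gap between the two is beyond the scatter. The two compounds differ in more than one place, so this gap is not read as the effect of any single group.

Compound 3 `Cc1cccc(NC(=O)CN2CCC(c3ccccc3)CC2)c1` is derived from compound 1 by one change: hydrogen in place of methoxy on an aromatic carbon. Among the compounds with values here, no pair among the measured compounds isolates this change, so there is no step to lean on, and the expectation rests on the single value of compound 1. The step expected here is a 1.9-fold higher number from compound 1 to compound 3 (0.28 log units; within the scatter), in the direction of a higher number, of a size that may or may not exceed the scatter. On that basis compound 3 is estimated at 800 nM, with a range from 250 nM to 2500 nM.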

Compound 3, half-maximal effective concentration: 170 nM
Compound 3: the middle estimate sits 4.7-fold (0.67 log units) above what was measured, and the stated range ends above it.
By their numbers in this assay, from the lowest: compounds 2 and 3 (each within the scatter of the next); then compound 1.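

Within this assay the change from methoxy to hydrogen on the aromatic carbon ortho to a large group gives a 2.5-fold lower number from compound 1 to compound 3 (0.39 log units; beyond the scatter) and is the first single-place step available in the series. On the core of compound 1, methoxy at this position is therefore not required for the effect, and the plain phenyl form needs less compound than the 2-methoxyphenyl form. No measured evidence bears on the origin of this step.

Still open, from the compounds shown here alone, is how a hydroxy group, an ethoxy group or a chlorine atom on the same carbon would compare with hydrogen and methoxy. Going by these compounds, this reading rests on a single pair, so whether the step carries over to cores other than that of compound 1 also remains open.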